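A few compounds are considered here, and "the series" means these few. Any claim that something is new, unique, unknown or untested is made for them only; others in the source may bear on it.

Measured so far in a functional assay on IMR-32 cells for inhibition of Voltage-dependent N-type calcium channel subunit alpha-1B (Homo sapiens), read by calcium flux; on this read-out higher numbers stand for weaker inhibition and lower numbers for stronger inhibition:
Compound 1 `COc1ccc(COC(=O)[C@@H](CC(=O)OC2CCCC2)NC(=O)OC(C)(C)C)cc1` gives 2000 nM.
Compound 2 `COc1ccc(COC(=O)[C@H](CC(=O)OC2CCCC2)NC(=O)OC(C)(C)C)cc1` gives 3400 nM.
Compound 3 `COc1ccc(COC(=O)[C@H](COC(=O)C2CCCCC2)NC(=O)OC(C)(C)C)cc1` gives 1600 nM.

Compound 2 has the highest number of the three. Its gap to compound 1 stays within the scatter, a 1.7-fold higher number from compound 1 to compound 2 (0.23 log units; within the scatter), and the fact that compounds 1 and 2 differ only in the configuration as drawn is all that separates them. Compound 3 lies lower, a 2.1-fold lower number from compound 2 to compound 3 (0.33 log units; beyond the scatter), after a change of the ester group on the chain.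

Compound 4 `CC(C)(C)OC(=O)N[C@@H](CC(=O)OC1CCCC1)C(=O)OCc1ccc(Br)cc1` differs from compound 2 by bromo in place of methoxy on an aromatic carbon. Neither measured step touches the aromatic ring: one alters configuration only, the other the chain ester. Nothing here therefore points to a step beyond the scatter in this assay, and compound 4 is expected to land near compound 2. Compound 4 is estimated at 3000 nM, between 1200 nM and 8000 nM. The expected step is a 1.1-fold lower number from compound 2 to compound 4 (0.05 log units; within the scatter), inside the scatter.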

Compound 4, half-maximal inhibitory concentration: 3400 nM
Compound 4: the middle estimate sits 1.1-fold (0.05 log units) below what was measured; the range from low to high includes it.
By their numbers in this assay, from the lowest: compounds 3, 1, 2 and 4 (each within the scatter of the next, the first and the last beyond it).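

Going by these compounds alone, the aromatic ring had not been varied among the earlier compounds, and in this assay bromo in place of methoxy, on the ring carbon para to a large group, gives no change at the digits printed from compound 2 to compound 4 (within the scatter). At this position, then, a one-atom group without a hydrogen-bond acceptor serves as well as methoxy. Nothing shown bears on why the number holds. As far as these compounds go, whether an amine, a carboxylic acid or a longer chain such as butoxy would also leave the number in place at this ring carbon remains open.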